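Restoring a Hydroxyl Donor on the Shared Core

A few compounds are considered here, and "the series" means these few. Any claim that something is new, unique, unknown or untested is made for them only; others in the source may bear on it.

Compound 1 `CC(=O)NCc1cccc(Cn2nc(NS(=O)(=O)c3ccc(Cl)s3)c3c(O)cccc32)c1` gives 12.6 nM in a functional assay on CHO cells for antagonist activity at C-C chemokine receptor type 4 (Homo sapiens), read by GTPgammaS binding; a lower number here means a stronger inhibitor, a higher number a weaker inhibitor. Compound 2 `CC(=O)NCc1cccc(Cn2nc(NS(=O)(=O)c3ccc(Cl)s3)c3c(C(C)=O)cccc32)c1` gives 100 nM in this assay, the highest of the two numbers; the step of a 7.9-fold higher number from compound 1 to compound 2 (0.90 log units; beyond the scatter) separates them. Compound 3 `CC(=O)NCc1cccc(Cn2nc(NS(=O)(=O)c3ccc(Cl)s3)c3c(C(C)O)cccc32)c1` differs from compound 2 by 1-hydroxyethyl in place of acetyl on an aromatic carbon, which brings back one hydrogen-bond donor. Within the data shown here, only the step of a 7.9-fold higher number from compound 1 to compound 2 (0.90 log units; beyond the scatter) bears on this change, and it was modest. A partial return toward the number of compound 1 is therefore expected, as a 2.5-fold lower number from compound 2 to compound 3 (0.40 log units; beyond the scatter). Compound 3 is estimated at 40 nM in this assay, within a range of 15 nM to 120 nM.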

Compound 3, half-maximal inhibitory concentration: 20 nM
Estimate against measurement, compound 3: 2.0-fold (0.30 log units) above, within the range that was stated.
By their numbers in this assay, from the lowest: compounds 1 and 3 (each within the scatter of the next); then compound 2.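

In this assay, 1-hydroxyethyl in place of acetyl gives a 5.0-fold lower number from compound 2 to compound 3 (0.70 log units; beyond the scatter), so the loss seen with acetyl is not shared by every group of 3 heavy atoms at this position. The step of a 1.6-fold higher number from compound 1 to compound 3 (0.20 log units; within the scatter) leaves hydroxy and 1-hydroxyethyl indistinguishable here, and both carry 1 hydrogen-bond donor where acetyl has 0. Nothing measured here explains this link between donor and number. As far as these compounds go, whether an amine or a methoxy group at this position would also keep the number low stays open. So does whether a longer chain, such as 2-hydroxyethyl, would be tolerated.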